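Taking Both Halogens Off Compound 3

The compounds below may be only part of what the source reports. "The series", "measured", "known", "first", "only" and "open" are said of these compounds alone.

Compound 1 `CNC(=O)c1cc(Oc2ccc(C3=NNC(c4ccc(Cl)cc4Cl)C3)cc2)ccn1`: 6930 nM
Compound 2 `CNC(=O)c1cc(Oc2ccc(C3=NNC(c4cc(OC)c(OC)c(OC)c4)C3)cc2)ccn1`: 37100 nM
Compound 3 `CNC(=O)c1cc(Oc2ccc(C3=NNC(c4ccc(F)cc4Cl)C3)cc2)ccn1`: 13700 nM

All three compounds were tested in a functional assay on A549 cells (Homo sapiens) for cytotoxicity, read by MTT assay, with a stated time of 72 h; a higher number here means a weaker inhibitor, a lower number a stronger inhibitor. Compound 3 stands level with compound 1 within the usual scatter of repeated measurements, and the gap up to compound 2 lies beyond that scatter.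

Compound 4 `CNC(=O)c1cc(Oc2ccc(C3=NNC(c4ccccc4)C3)cc2)ccn1` has not yet been measured. Its structure departs from compound 3 in one place: phenyl in place of 2-chloro-4-fluorophenyl on a saturated ring carbon. Put simply, compound 4 carries neither of the two halogens of compound 3.

Within the data shown here, only one measured step bears on this change: a 2.0-fold higher number from compound 1 to compound 3 (0.30 log units; within the scatter). That step swaps chloro for fluoro and stays within the scatter, yet it removes neither halogen outright, so it is a partial guide. Among the measured compounds shown here, no measured compound carries a plain phenyl, so the data offer no direct comparison. The higher number of compound 2 at 37100 nM shows how far the values in this small set spread, and that keeps the range wide.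

The expected change is a 1.3-fold higher number from compound 3 to compound 4 (0.12 log units; within the scatter), so only a slight rise and nothing beyond the scatter is expected. For compound 4 the estimated value is 18000 nM, with an expected range from 8000 nM to 40000 nM.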

Compound 4, half-maximal inhibitory concentration: 8600 nM
The estimate for compound 4 lay 2.1-fold (0.32 log units) above the measured number, within the range that was stated.
By their numbers in this assay, from the lowest: compounds 1, 4 and 3 (each within the scatter of the next); then compound 2.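

Until now, every measured compound carried something on this phenyl ring, so the set could not show whether those groups were needed at all. In this assay, replacing 2-chloro-4-fluorophenyl with plain phenyl gives a 1.6-fold lower number from compound 3 to compound 4 (0.20 log units; within the scatter) and replacing 2,4-dichlorophenyl with plain phenyl gives a 1.2-fold higher number from compound 1 to compound 4 (0.09 log units; within the scatter), so on this saturated ring carbon the unsubstituted ring stands level with both dihalogenated rings. Neither halogen pair is therefore needed to reach this level of cytotoxicity, and among these compounds only the three methoxy groups of compound 2 set a number clearly apart, with compound 2 at 37100 nM against the plain phenyl of compound 4 at 8600 nM.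

On these data alone, it remains open whether a single chloro or fluoro, or a quite different group on this ring such as an amine or a carboxylic acid, would move the number beyond the scatter in either direction. Nothing in the data shown explains why removing the halogens changes so little.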